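Compound 3 to compound 4: back to a phenyl

This account rests on a few compounds, and the source may have more. Where it says the series, first, only, none or still open, it means among the compounds named here.

Among the measured compounds shown here, compound 3 `COc1cc(C(=O)c2sc(-c3ccsc3)cc2N)cc(OC)c1OC` gives 9.6 nM in a functional assay on CCRF-CEM cells (Homo sapiens) for antiproliferative activity (on this read-out higher numbers stand for weaker inhibition and lower numbers for stronger inhibition), the lowest of the three numbers so far. Compound 1 `COc1cc(C(=O)c2sc(-c3ccc(Br)cc3)cc2N)cc(OC)c1OC` gives 86 nM and compound 2 `COc1cc(C(=O)c2sc(-c3ccc(I)cc3)cc2N)cc(OC)c1OC` gives 150 nM, and a 1.7-fold higher number from compound 1 to compound 2 (0.24 log units; within the scatter) stays within the scatter. Compound 4 `COc1ccc(-c2cc(N)c(C(=O)c3cc(OC)c(OC)c(OC)c3)s2)cc1` has 4-methoxyphenyl in place of thiophen-3-yl on an aromatic carbon. The closest evidence is a 9.0-fold lower number from compound 1 to compound 3 (0.95 log units; beyond the scatter) and a 16-fold lower number from compound 2 to compound 3 (1.19 log units; beyond the scatter), both beyond the scatter, with thiophen-3-yl entering in place of a 4-substituted phenyl. For the measured compounds named here, no methoxy-bearing compound has been measured, so only part of that gap is expected to reopen. The expected step is a 4.2-fold higher number from compound 3 to compound 4 (0.62 log units; beyond the scatter), a rise beyond the scatter. For compound 4 the estimated value is 40 nM, with an expected range of 12 nM to 130 nM.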

Compound 4, half-maximal inhibitory concentration: 19 nM
Compound 4: the middle estimate sits 2.1-fold (0.32 log units) above what was measured, and the stated range covers the measured number.
By their numbers in this assay, from the lowest: compounds 3 and 4 (each within the scatter of the next); then compounds 1 and 2 (each within the scatter of the next).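

Working notes: on the aromatic carbon next to the ring sulfur, a six-membered aromatic ring need not lose ground to thiophen-3-yl in this assay (a 2.0-fold higher number from compound 3 to compound 4 (0.30 log units; within the scatter)). The group carried by that phenyl counts, as methoxy in place of halogen gives (a 4.5-fold lower number from compound 1 to compound 4 (0.66 log units; beyond the scatter)) and (a 7.9-fold lower number from compound 2 to compound 4 (0.90 log units; beyond the scatter)). No available data explain these steps.

Open: whether an amine, a hydroxyl or a longer alkoxy chain in place of methoxy keeps the number within the scatter of compound 3.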